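Notes on compound 4: iodo in place of ethyl

The source may report more compounds than this note shows. Statements on the series, on what has been measured and on what is new or still open speak of the compounds shown alone.

Measured so far in an ADME assay on the whole organism with Oryza sativa as the target, tested at 0.1 uM; a lower number here means a stronger effect, a higher number a weaker effect of the compound at the concentration tested:
compound 1, `CCc1ccc(NC(=O)N[C@H](C)c2ccccc2)cc1`, gives 95%
compound 2, `CCc1ccc(NC(=O)N[C@@H](C)c2ccccc2)cc1`, gives 99%
compound 3, `C[C@H](NC(=O)Nc1ccccc1Br)c1ccccc1`, gives 101%

All three numbers sit within the scatter of one another. Compound 2 is separated from compound 3 and from compound 1 by less than the scatter, so no order among them can be read. Going by the values given here, the one step available, a number 4 percentage points higher from compound 1 to compound 2 (within the scatter), rests on the fact that compounds 1 and 2 differ only in the configuration as drawn and says nothing about substituents on the aromatic ring.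

Compound 4, `C[C@H](NC(=O)Nc1ccc(I)cc1)c1ccccc1`, is not yet measured. Against compound 2 the change is iodo in place of ethyl on an aromatic carbon. Among the compounds with values here, no measured step touches this exchange: compound 3 carries a halogen but differs from compound 4 in more than one place, and its value only shows that a halogen-bearing analogue sits in the same band as the others. Without a bearing step, no movement beyond the scatter is expected in this assay; the estimated step is a number 1 percentage points lower from compound 2 to compound 4 (within the scatter). Compound 4 is expected to give about 98%, within 88% to 108%.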

Compound 4, a percentage reported as activity, at one concentration (the size of the read-out at that concentration, not a potency): 99%
Compound 4: the middle estimate sits 1 percentage points below what was measured; the range from low to high includes it.
By their numbers in this assay, from the lowest: compounds 1, 2, 4 and 3 (each within the scatter of the next).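

Going by these compounds alone, for this assay, iodo in place of ethyl on an aromatic carbon, para to a large group, gives no change at the digits printed from compound 2 to compound 4 (within the scatter) and so supplies a step at this position, which the earlier compounds could not give. At this position, then, a single iodine atom can stand where the 2 carbon atoms of ethyl stood without a reading outside the scatter, though this rests on one exchange only. No measured fact available bears on this exchange.

On these data alone, whether an amine, a carboxylic acid or a longer chain at this position would give a step beyond the scatter remains open. With the four compounds shown all in one band, it also remains open which structural change, if any, separates compounds in this assay.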